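Fluoro in Place of Methoxy: Expected Cytotoxicity of Compound 3

The compounds below may be only part of what the source reports. "The series", "measured", "known", "first", "only" and "open" are said of these compounds alone.

Two compounds have so far been measured in a functional assay on A549 cells (Homo sapiens) for cytotoxicity, read by MTT assay, with a stated time of 48 h; on this read-out lower numbers stand for stronger inhibition and higher numbers for weaker inhibition:
compound 1, `COc1ccc(OC)c(C2=NOC(COc3ccc(-c4nnnn4-c4cc(OC)c(OC)c(OC)c4)cc3N)C2)c1`, gives 1930 nM;
compound 2, `COc1cc(C2=NOC(c3cc(OC)c(OC)c(OC)c3)C2)ccc1O`, gives 2600 nM.

Compound 1 holds the lower of the two numbers, yet compound 2 lies within the scatter of repeated measurements of this kind, so the two cannot be ranked against each other. Among the measured compounds shown here, no pair of measured compounds differs in a single place, so no measured step is available as a guide.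

Compound 3, `COc1ccc(F)c(C2=NOC(COc3ccc(-c4nnnn4-c4cc(OC)c(OC)c(OC)c4)cc3N)C2)c1`, has not yet been measured. It is derived from compound 1 by one change: fluoro in place of methoxy on an aromatic carbon. The group that leaves and the group that enters occupy the same aromatic carbon of a six-membered aromatic ring of carbon only, ortho to a large group and para to a methoxy group; cut one bond further out, the change reads 2,5-dimethoxyphenyl to 2-fluoro-5-methoxyphenyl.

With no measured step of this kind in the set, the expectation for compound 3 rests on compound 1 alone. In this assay the expected step is a 1.0-fold higher number from compound 1 to compound 3 (0.02 log units; within the scatter), that is, nothing beyond the scatter in either direction. Compound 3 is therefore estimated at 2000 nM, with a range from 900 nM to 4500 nM.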

Compound 3, half-maximal inhibitory concentration: 1510 nM
For compound 3 the middle estimate is 1.3-fold (0.12 log units) above the measured one; low and high end bracket the measured number.
By their numbers in this assay, from the lowest: compounds 3, 1 and 2 (each within the scatter of the next).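

In this assay, among the compounds shown here, the step at this position is a 1.3-fold lower number from compound 1 to compound 3 (0.11 log units; within the scatter), the first measured exchange on the aromatic carbon ortho to a large group and para to a methoxy group. It shows that the 2,5-dimethoxyphenyl of compound 1 can give way to the 2-fluoro-5-methoxyphenyl of compound 3 without a change that can be told from the scatter, so the methoxy group at this place is not required to keep the number at this level. The methoxy group that leaves counts 2 heavy atoms and 1 hydrogen-bond acceptor, the fluoro that enters 1 heavy atom and 0 hydrogen-bond acceptors, but nothing available explains why the exchange gives this outcome.

The compounds shown leave open whether another group on this same carbon, such as an amine, a chloro or a carboxylic acid, would move the number beyond the scatter in this assay. They also leave open whether fluoro in place of the remaining methoxy group of this ring would give a step of similar size.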